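Shared core: the step from compound 2 to compound 3

The source may report more compounds than this note shows. Statements on the series, on what has been measured and on what is new or still open speak of the compounds shown alone.

Compound 1 `COc1cc(NC(=O)Nc2cc(Nc3ccc(C)c(F)c3)ncn2)cc(OC)c1` and compound 2 `COc1cc(NC(=O)Nc2cc(Nc3ccc(F)c(Cl)c3)ncn2)cc(OC)c1` share one core and differ only in the aryl on the nitrogen. Going by the values given here, in a functional assay on NCI-H226 cells (Homo sapiens) for inhibition, read by MTT assay, with a stated time of 48 h, tested at 10 uM (a higher number here means more inhibition at the concentration tested (going by the name of the read-out), a lower number less inhibition), compound 1 gives 39.7%, and compound 2 gives 36.7%; the step of a number 3 percentage points lower from compound 1 to compound 2 (within the scatter) lies within the scatter, so compound 2 stands within the scatter of compound 1 on the two numbers known. Compound 3 `COc1cc(NC(=O)Nc2cc(Nc3cc(F)ccc3OC)ncn2)cc(OC)c1` is unmeasured and carries 5-fluoro-2-methoxyphenyl in place of 3-chloro-4-fluorophenyl on a nitrogen on an aromatic ring. Among the compounds with values here, only the step from compound 1 to compound 2 bears on this change, an aryl swap at the same place, and it stayed within the scatter, so no step beyond the scatter is expected in this assay. Compound 3 is therefore estimated at 36% with a range of 22% to 50%. This estimate means an expected a number 0.7 percentage points lower from compound 2 to compound 3 (within the scatter).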

Compound 3, a percentage reported as inhibition, at one concentration (the size of the read-out at that concentration, not a potency): 37.7%
The estimate for compound 3 lay 1.7 percentage points below the measured number, and the stated range covers the measured number.
By their numbers in this assay, from the lowest: compounds 2, 3 and 1 (each within the scatter of the next).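

In this assay the 5-fluoro-2-methoxyphenyl group gives a number 1 percentage points higher from compound 2 to compound 3 (within the scatter) and a number 2 percentage points lower from compound 1 to compound 3 (within the scatter) on the same nitrogen. Unlike the earlier swap, this change brings a hydrogen-bond acceptor into the aryl group, yet all three aryl groups on this nitrogen remain within the scatter of one another. Nothing available explains this flat reading. Still open, on these data alone, is whether a dimethylamino group or a carboxylic acid on this aryl ring, or a plain butyl chain in its place, would shift the number beyond the scatter.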